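The source may report more compounds than this note shows. Statements on the series, on what has been measured and on what is new or still open speak of the compounds shown alone.

In a functional assay on SK-OV-3 cells (Homo sapiens) for antiproliferative activity, read by MTT assay, with a stated time of 72 h (on this read-out lower numbers stand for stronger inhibition and higher numbers for weaker inhibition), compound 1 (`COc1cc(OC)cc(-c2cccc(NC(=O)CCc3cccc4c3COB4O)c2)c1`) gives 88000 nM and compound 2 (`CC(=O)c1ccc(-c2cccc(NC(=O)CCc3cccc4c3COB4O)c2)cc1`) gives 57000 nM. These two numbers lie within the usual scatter of each other, so compound 2 cannot be ranked apart from compound 1. Compound 3 (`CC(=O)c1ccc(-c2cccc(NC(=O)CCc3cccc4c3C(O)OC4)c2)cc1`) keeps the 4-acetylphenyl group of compound 2 but differs elsewhere: a group of 10 heavy atoms (8 carbon, 2 oxygen; one five-membered non-aromatic ring with 1 hetero atom, one six-membered aromatic ring of carbon only) in place of a group of 10 heavy atoms (7 carbon, 1 boron, 2 oxygen; one five-membered non-aromatic ring with 2 hetero atoms, one six-membered aromatic ring of carbon only), on a saturated chain carbon, two bonds along the chain from a carbonyl carbon. In plain terms, a group containing boron gives way to one with only carbon and oxygen, while the ring sizes stay the same.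

For the measured compounds named here, only one measured step is available, a 1.5-fold lower number from compound 1 to compound 2 (0.19 log units; within the scatter), and it lies within the scatter. That step concerns a different place in the molecule, so it offers only weak guidance, showing just that one change elsewhere left the number within the scatter. Going by the values given here, no measured pair shows what replacing this group does in this assay, so no step beyond the scatter is expected, and no firm direction can be given. The expected change is a 1.2-fold higher number from compound 2 to compound 3 (0.09 log units; within the scatter), a small estimated step. For compound 3, the estimated value is 70000 nM, within an expected range from 25000 nM to 180000 nM.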

Compound 3, half-maximal inhibitory concentration: 41000 nM
Beside the measured number, compound 3's estimate is 1.7-fold (0.23 log units) above it; measured number inside the range.
By their numbers in this assay, from the lowest: compounds 3, 2 and 1 (each within the scatter of the next, the first and the last beyond it).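

For the compounds shown here, for the first time, the change falls on the group that carries boron, on a saturated chain carbon, two bonds along the chain from a carbonyl carbon, rather than on the 4-acetylphenyl group that sets compound 2 apart from compound 1. In this assay, exchanging the boron-containing group for one holding only carbon and oxygen, with the same ring sizes and the same counts of hydrogen-bond donors and acceptors, gives a 1.4-fold lower number from compound 2 to compound 3 (0.14 log units; within the scatter), so this single pair offers no sign that boron matters to the number in this assay. No measurement is at hand that would explain this result.

Going by these compounds alone, whether the same exchange would behave alike with the 3,5-dimethoxyphenyl group of compound 1 stays open, as it is seen here in only one pair. Also open, from the compounds shown here alone, is what a quite different group at this place would do, such as a carboxylic acid or an amine, or what a longer chain leading to the ring-bearing group would do, and whether any such change would move the number by more than the scatter.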